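The compounds below may be only part of what the source reports. "The series", "measured", "known", "first", "only" and "open" are said of these compounds alone.

Measured in a functional assay on B16-F10 cells (Mus musculus) for antiproliferative activity, read by MTT assay, with a stated time of 48 h; a lower number here means a stronger inhibitor, a higher number a weaker inhibitor:
- compound 1 `CC(=O)N1N=C(c2ccc3ccccc3c2)OC1c1ccccc1`: 2.57 ug/mL
- compound 2 `CC(=O)N1N=C(c2ccc3ccccc3c2)OC1c1ccc(Br)cc1`: 4.68 ug/mL
- compound 3 `CC(=O)N1N=C(c2ccc3ccccc3c2)OC1c1ccc(Cl)cc1`: 2.48 ug/mL

In this assay, compound 3 cannot be separated from the other two measured compounds. Both a 1.0-fold lower number from compound 1 to compound 3 (0.02 log units; within the scatter) and a 1.9-fold lower number from compound 2 to compound 3 (0.28 log units; within the scatter) lie within the scatter. The unmeasured compound 4 `CC(=O)N1N=C(c2ccc3ccccc3c2)OC1c1ccc(OCc2ccccc2)cc1` keeps the shared core and carries benzyloxy in place of chloro on an aromatic carbon.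

Within the data shown here, no measured compound holds this group, so the only evidence comes from the other changes at the same place. Beside the two steps already given, a 1.8-fold higher number from compound 1 to compound 2 (0.26 log units; within the scatter) also stays within the scatter. These steps exchange only hydrogen, chloro and bromo, so they say little about a group as large as benzyloxy. They give no reason to expect a step beyond the scatter in either direction, but they constrain it only loosely, and the range must stay wide. The estimate amounts to an expected 1.4-fold higher number from compound 3 to compound 4 (0.15 log units; within the scatter), which is no firm call on direction. Compound 4 is expected at 3.5 ug/mL, with an estimated range of 1.4 ug/mL to 9 ug/mL.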

Compound 4, half-maximal inhibitory concentration: 8.08 ug/mL
The estimate for compound 4 lay 2.3-fold (0.36 log units) below the measured number; low and high end bracket the measured number.
By their numbers in this assay, from the lowest: compounds 3, 1, 2 and 4 (each within the scatter of the next, the first and the last beyond it).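

In this assay, among these compounds, changes on this aromatic carbon, para to a large group, now give steps beyond the scatter for the first time. Benzyloxy in place of chloro gives a 3.3-fold higher number from compound 3 to compound 4 (0.51 log units; beyond the scatter), and benzyloxy in place of hydrogen gives a 3.1-fold higher number from compound 1 to compound 4 (0.50 log units; beyond the scatter), both of modest size and both towards a weaker inhibitor. Benzyloxy in place of bromo gives only a 1.7-fold higher number from compound 2 to compound 4 (0.24 log units; within the scatter), so compound 4 cannot be separated from compound 2, and the larger group with its added aromatic ring stands apart from hydrogen and chloro but not from bromo. Nothing at hand bears on why compound 4 differs from compound 1 and compound 3.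

On these data alone, it stays open whether methoxy at this place would read with compound 1 and compound 3, which would tell the ether oxygen apart from the added aromatic ring as the part that goes with the higher number. How an amine or a carboxylic acid at this place would read in this assay also stays open, as the compounds shown carry only hydrogen, halogens and benzyloxy here.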